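Extending the 4-methylpiperidin-1-yl group: compound 3 to compound 4

The source may hold more compounds than are shown below. What is called first, only, known or untested is meant among the compounds shown, and "the series" means these compounds.

Compound 1 `CCCN(CCC)c1cc(C(F)(F)F)ccc1CNC(=O)C(C)c1ccc(NS(C)(=O)=O)c(F)c1` is the reference of the series; in an assay on CHO cells for antagonist activity at transient receptor potential cation channel subfamily V member 1 (Homo sapiens), read by FLIPR (on this read-out lower numbers stand for stronger inhibition and higher numbers for weaker inhibition), compound 1 gives 0.3 nM. Compound 2 `CC(C(=O)NCc1ccc(C(F)(F)F)cc1N1CCCCCC1)c1ccc(NS(C)(=O)=O)c(F)c1` gives 1.6 nM, a change of a 5.3-fold higher number from compound 1 to compound 2 (0.73 log units; beyond the scatter). Compound 3 `CC1CCN(c2cc(C(F)(F)F)ccc2CNC(=O)C(C)c2ccc(NS(C)(=O)=O)c(F)c2)CC1` gives 0.9 nM, so a 3.0-fold higher number from compound 1 to compound 3 (0.48 log units; beyond the scatter) and a 1.8-fold lower number from compound 2 to compound 3 (0.25 log units; within the scatter); compound 3 therefore stands second highest of the three numbers, separated from compound 2 only within the scatter and from compound 1 beyond it.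

Compound 4 `CCC1CCN(c2cc(C(F)(F)F)ccc2CNC(=O)C(C)c2ccc(NS(C)(=O)=O)c(F)c2)CC1` differs from compound 3 by methyl in place of hydrogen on a saturated chain carbon bound to a saturated ring carbon. For the measured compounds named here, no measured step covers this change; the steps among compounds 1, 2 and 3 exchange whole amine groups and all remain modest. A single added carbon is expected to move the number little, if at all, so for compound 4 the step of a 1.1-fold higher number from compound 3 to compound 4 (0.05 log units; within the scatter) is expected to stay within the scatter. Compound 4 is estimated at 1 nM, range 0.4 nM to 2.5 nM.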

Compound 4, inhibition constant: 0.7 nM
Estimate against measurement, compound 4: 1.4-fold (0.15 log units) above; the measured number falls inside the stated range.
By their numbers in this assay, from the lowest: compound 1; then compounds 4, 3 and 2 (each within the scatter of the next, the first and the last beyond it).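

Replacing 4-methylpiperidin-1-yl with 4-ethylpiperidin-1-yl gives a 1.3-fold lower number from compound 3 to compound 4 (0.11 log units; within the scatter), so this position accepts the added methyl with no change beyond the scatter. Compound 3 stood within the scatter of compound 2, but the ethyl analogue separates from azepan-1-yl, with a 2.3-fold lower number from compound 2 to compound 4 (0.36 log units; beyond the scatter), while still trailing dipropylamino, with a 2.3-fold higher number from compound 1 to compound 4 (0.37 log units; beyond the scatter). No evidence bearing on these steps is available.

Going by these compounds, whether a propyl or longer chain in place of ethyl holds the number in this range remains open. So does the outcome of placing a carboxylic acid or an amine on that chain.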